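The source may report more compounds than this note shows. Statements on the series, on what has been measured and on what is new or still open speak of the compounds shown alone.

Measured compounds in an assay on HT-29 cells for inhibition of Serine-protein kinase ATM (Homo sapiens), read by fluorescence, with a stated time of 1 h; a higher number here means a weaker inhibitor, a lower number a stronger inhibitor:
compound 1, `CCC(CC)CNc1c(C(N)=O)cnc2ccc(C#N)cc12`: 820 nM
compound 2, `C[C@@H](Nc1c(C(N)=O)cnc2ccc(-c3cccnc3)cc12)c1ccc(Cl)cc1`: 109 nM
compound 3, `CNC(=O)c1cnc2ccc(-c3cccnc3)cc2c1N[C@H](C)c1ccc(Cl)cc1`: reported only as a limit, > 30000 nM

Compound 2 holds the lowest of the two numbers available in this assay; compound 1 stands higher at 820 nM. Compound 3 sits at the limit of > 30000 nM in this assay, at which 1 of the 3 values shown sits.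

Within the data shown here, the only single-point step measured is an at least 270-fold higher number from compound 2 to compound 3 (2.43 log units; beyond the scatter), a change of methyl for hydrogen on the amide-type nitrogen. Compound 4, `CCC(CC)CNc1c(C(N)=O)cnc2ccc(-c3cccnc3)cc12`, keeps that nitrogen unchanged and instead differs from compound 2 by 2-ethylbutyl in place of 1-(4-chlorophenyl)ethyl on a nitrogen on an aromatic ring. The measured step therefore does not bear on it. Among the measured compounds shown here, compound 1 carries the same 2-ethylbutyl group, but differs from compound 2 in more than one place, so no step for the amine substituent alone is available; its number in this assay is simply higher than that of compound 2.

For compound 4 a number between those of compound 2 and compound 1 is expected, with a 3.7-fold higher number from compound 2 to compound 4 (0.56 log units; beyond the scatter) as the expected step upward. The estimate for compound 4 in this assay is 400 nM, within 120 nM to 1500 nM.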

Compound 4, half-maximal inhibitory concentration: 73 nM
For compound 4 the middle estimate is 5.5-fold (0.74 log units) above the measured one; measured number below the stated range.
By their numbers in this assay, from the lowest: compounds 4 and 2 (each within the scatter of the next); then compound 1. At a limit, above all of these: compound 3.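

On the nitrogen on an aromatic ring, 2-ethylbutyl in place of 1-(4-chlorophenyl)ethyl gives a 1.5-fold lower number from compound 2 to compound 4 (0.17 log units; within the scatter) in this assay, so these two substituents are not told apart here, although 2-ethylbutyl has no ring and no defined stereocentre. Among these compounds, with 2-ethylbutyl held on that nitrogen, the aromatic carbon gives the first large single-place step on that side of the series, with pyridin-3-yl in place of cyano: an 11-fold lower number from compound 1 to compound 4 (1.05 log units; beyond the scatter). Nothing shown accounts for either step.

Still open, on these data alone, is whether the pyridin-3-yl step carries over when 1-(4-chlorophenyl)ethyl sits on the nitrogen, and how phenyl or a carboxylic acid would read on that aromatic carbon. As far as these compounds go, on the nitrogen, it also remains open how far the tolerance extends, for example to a longer chain or a chain ending in an amine.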